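Swapping the Pyridine Nitrogen Out of a Urea Antagonist

This account rests on a few compounds, and the source may have more. Where it says the series, first, only, none or still open, it means among the compounds named here.

Compound 1, `Cc1cc(CNC(=O)c2cc(Cl)nc(Cl)c2)ncc1-c1cn(C)nc1C`: in a functional assay on CHO cells for antagonist activity at sphingosine 1-phosphate receptor 2 (Homo sapiens), read by scintillation counting and GTPgammaS binding, with a stated time of 4 h, in the presence of a further agent that is not named here (a higher number here means a weaker inhibitor, a lower number a stronger inhibitor), compound 1 gives only a limit, > 100 nM.
Compound 2, `Cc1cc(CNC(=O)Nc2cc(Cl)nc(Cl)c2)ncc1-c1cn(C)nc1C`: in this assay compound 2 gives 0.77 nM.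
Compound 3, `CCOc1cc(NC(=O)NCc2cc(C)c(-c3cn(C)nc3C)cn2)cc(Cl)n1`: in this assay compound 3 gives 0.32 nM.

Among the two real numbers, compound 2 stands highest, and its nearest neighbour is compound 3, a step of a 2.4-fold lower number from compound 2 to compound 3 (0.38 log units; beyond the scatter). Compound 1 sits at a limit of the assay, (the limit of > 100 nM in this assay, at which 1 of the 3 values shown sits), so it gives no number to rank.

Compound 4, `Cc1cc(CNC(=O)Nc2cc(Cl)cc(Cl)c2)ncc1-c1cn(C)nc1C`, is the next compound. It differs from compound 2 by 3,5-dichlorophenyl in place of 2,6-dichloropyridin-4-yl on an amide-type nitrogen.

Two measured steps give some bearing. The step of an at least 120-fold lower number from compound 1 to compound 2 (2.11 log units; beyond the scatter) shows that inserting the urea nitrogen between the carbonyl and the dichlorinated ring mattered greatly. The step of a 2.4-fold lower number from compound 2 to compound 3 (0.38 log units; beyond the scatter) shows that swapping a chloro on that ring for an ethoxy moved the number only modestly. Neither step removes the ring nitrogen itself, so they frame the change only loosely: the ring tolerates a substituent swap, but the urea linker is sensitive. A modest step is therefore expected, leaning toward a higher number.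

For compound 4 the estimated step is a 2.6-fold higher number from compound 2 to compound 4 (0.41 log units; beyond the scatter). Compound 4 is expected to give 2 nM, within a range from 0.5 nM to 10 nM.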

Compound 4, half-maximal inhibitory concentration: 0.3 nM
Compound 4: the middle estimate sits 6.7-fold (0.82 log units) above what was measured; the measured number lies below the stated range.
By their numbers in this assay, from the lowest: compounds 4 and 3 (each within the scatter of the next); then compound 2. At a limit, above all of these: compound 1.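

Taking the ring nitrogen out does not cost activity at this amide-type nitrogen: in this assay, putting 3,5-dichlorophenyl in place of 2,6-dichloropyridin-4-yl gives a 2.6-fold lower number from compound 2 to compound 4 (0.41 log units; beyond the scatter), so the hydrogen-bond acceptor counted on the departing ring is not required for a low number in this series. The urea link also stays valuable with the carbon-only ring, with an at least 330-fold lower number from compound 1 to compound 4 (2.52 log units; beyond the scatter), although that step carries the added amide-type nitrogen and the ring swap together, so it cannot be split between them. Its size is only a lower bound, as compound 1 gives a limit of the assay and not a number: the limit of > 100 nM in this assay, at which 1 of the 4 values shown sits.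

As far as these compounds go, it remains open whether the ethoxy group that was tolerated on the pyridine ring of compound 3 would behave the same way on the carbon-only ring, and whether a methoxy group, an amine or a carboxylic acid could stand in place of a chloro there. The compounds shown also leave open why the ring nitrogen can go, as a single assay gives the size of this change and nothing about its cause.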